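Swapping the aryl group on the core of compound 1

The source may report more compounds than this note shows. Statements on the series, on what has been measured and on what is new or still open speak of the compounds shown alone.

Of the compounds shown here, three sharing one core have been measured in an assay on Sf9 cells for inhibition of protein deacetylase HDAC6 (Homo sapiens), read by fluorescence, with a stated time of 40 min, tested at 100 nM; a lower number here means less inhibition, a higher number more inhibition at the concentration tested (going by the name of the read-out). Compound 1 `Cc1cccc(-c2nc(CNc3ccc(C(=O)NO)cc3)n(-c3ccccc3)n2)c1` gives 64.1%. Compound 2 `O=C(NO)c1ccc(NCc2nc(-c3ccccc3)nn2-c2cccc(Cl)c2)cc1` gives 62.3%, and compound 3 `CC(C)c1ccc(-n2nc(-c3ccccc3)nc2CNc2ccc(C(=O)NO)cc2)cc1` gives 52.6%. For the measured compounds named here, of the three numbers, the one for compound 1 is the highest; compound 2 sits within the scatter of it, while compound 3 lies beyond it. Going by the values given here, the only step between two measured compounds that differ in one place is a number 9.7 percentage points lower from compound 2 to compound 3 (within the scatter), and it concerns the group on the aromatic nitrogen of the core, not the group on the aromatic carbon.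

Compound 4 `O=C(NO)c1ccc(NCc2nc(-c3ccncc3)nn2-c2ccccc2)cc1` differs from compound 1 in one place: pyridin-4-yl in place of 3-methylphenyl on an aromatic carbon. Among the compounds with values here, no measured pair changes the group on that aromatic carbon, so nothing measured bears directly on this step. Within the data shown here, the one measured step, a number 9.7 percentage points lower from compound 2 to compound 3 (within the scatter), alters a different part of the core and stays within the scatter. Among the measured compounds shown here, with no direct precedent, the expected step is a number 8.1 percentage points lower from compound 1 to compound 4 (within the scatter), a change not expected to reach beyond the scatter in either direction. In this assay compound 4 is therefore estimated at 56%, with a range from 36% to 74%.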

Compound 4, a percentage reported as inhibition, at one concentration (the size of the read-out at that concentration, not a potency): 30.8%
Beside the measured number, compound 4's estimate is 25.2 percentage points above it; the measured number lies below the stated range.
By their numbers in this assay, from the lowest: compound 4; then compounds 3, 2 and 1 (each within the scatter of the next, the first and the last beyond it).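

In this assay, the group on the aromatic carbon between two ring nitrogen atoms proves able to move the read-out by a large margin: a number 33.3 percentage points lower from compound 1 to compound 4 (beyond the scatter) is the first step among these compounds to lie beyond the scatter, whereas a number 9.7 percentage points lower from compound 2 to compound 3 (within the scatter) on the aromatic nitrogen stayed within it. The change to the six-membered aromatic ring at this position is a small one in count, with a single ring nitrogen and one hydrogen-bond acceptor entering and the methyl group leaving, yet it is enough to give this step. No measurement at hand accounts for the drop, so the result records its size and not its cause.

The step joins two changes, the loss of the methyl group and the arrival of the ring nitrogen, and the compounds shown cannot separate them. Plain phenyl on this aromatic carbon, with the phenyl group on the aromatic nitrogen kept, would isolate the methyl group, while pyridin-3-yl or pyridin-2-yl would show whether the place of the ring nitrogen matters.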